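Swapping pyrazolylmethyl for phenyl in compound 1

A few compounds are considered here, and "the series" means these few. Any claim that something is new, unique, unknown or untested is made for them only; others in the source may bear on it.

Measured in an ADME assay on liver for metabolic stability, with Liver microsome (Homo sapiens) as the target, read by LC-MS, using microsomes; a lower number here means slower removal, a higher number faster removal of the compound:
- Compound 1 `O=C(NCc1cc(Cl)ccc1-n1cnnn1)[C@@H]1C[C@@H]2C[C@@H]2N1C(=O)[C@H](O)Cn1cccn1` gives < 12 mL.min-1.g-1 (a limit of the assay)
- Compound 2 `O=C(NCc1cc(Cl)ccc1-n1cnnn1)[C@@H]1CC=NN1C(=O)[C@H](O)c1ccccc1` gives < 12 mL.min-1.g-1 (a limit of the assay)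
- Compound 3 `CC(C)(C)[C@@H](O)C(=O)N1CSC(C)(C)[C@H]1C(=O)NCc1cc(Cl)ccc1-n1cnnn1` gives 360 mL.min-1.g-1

Compound 1 has no exact number in this assay and stands at the limit of < 12 mL.min-1.g-1 in this assay, at which 2 of the 3 values shown sit. Its true value could lie anywhere under that limit. Compound 3, in contrast, has a measured number, which shows that the assay can return high readings for a compound of this set.

Compound 4 `O=C(NCc1cc(Cl)ccc1-n1cnnn1)[C@@H]1C[C@@H]2C[C@@H]2N1C(=O)[C@H](O)c1ccccc1` carries phenyl in place of (1H-pyrazol-1-yl)methyl on a saturated chain carbon bound to a carbonyl carbon and an oxygen on a saturated carbon. Going by the values given here, no measured pair isolates this change, so the direction and size of its effect remain a judgement. A modest rise in this assay is expected, possibly small enough to leave the reading at the limit. The expected step is an at least 1.6-fold higher number from compound 1 to compound 4 (0.22 log units; that floor lies within the scatter). In this assay the estimate for compound 4 is 20 mL.min-1.g-1, with an expected range from 10 mL.min-1.g-1 to 60 mL.min-1.g-1.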

Compound 4, intrinsic clearance in microsomes: < 16 mL.min-1.g-1
Compound 4 ended at the assay's limit; the forecaster's own chance of this, stated with the estimate: 40%; middle value at least 1.2-fold (0.09 log units) away from the limit.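

Compound 1 and compound 4 both read as limits in this assay, and no step can be read between them. The compounds shown leave open whether phenyl in place of (1H-pyrazol-1-yl)methyl changes intrinsic clearance at all, and if it does, in which direction and by how much.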